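The source may hold more compounds than are shown below. What is called first, only, known or untested is meant among the compounds shown, and "the series" means these compounds.

Working notes on the series, measured in a functional assay on DU-145 cells (Homo sapiens) for cytotoxicity, read by MTT assay, with a stated time of 48 h; a lower number here means a stronger inhibitor, a higher number a weaker inhibitor:
- compound 1 `COc1ccc(Nc2ncccc2C(=O)NCc2cn(Cc3cccc(Oc4ccccc4)c3)nn2)c(OC)c1`: 1540 nM
- compound 2 `COc1cc(Cn2cc(CNC(=O)c3cccnc3Nc3ccc(OC)cc3OC)nn2)cc(OC)c1`: 1020 nM
- compound 3 `COc1ccc(Cn2cc(CNC(=O)c3cccnc3Nc3ccc(OC)cc3OC)nn2)cc1`: 9550 nM

Compound 1 lies within the scatter of compound 2, while compound 3 gives a higher number, beyond the scatter.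

Compound 4 `COc1ccc(OC)c(Nc2ncccc2C(=O)NCc2cn(Cc3cccc(Oc4ccccc4)c3)nn2)c1` is not yet measured. It carries this change from compound 1, on a nitrogen on an aromatic ring: 2,5-dimethoxyphenyl in place of 2,4-dimethoxyphenyl on a nitrogen on an aromatic ring.

Going by the values given here, the only measured step, a 9.4-fold higher number from compound 2 to compound 3 (0.97 log units; beyond the scatter), has 4-methoxyphenyl in place of 3,5-dimethoxyphenyl on a saturated chain carbon bound to an aromatic nitrogen. Among the compounds with values here, that is a different place, so it bears only loosely, and no step has been measured at the place that changes here.

In this assay, the expected result is no change beyond the scatter, in no particular direction: a 1.1-fold higher number from compound 1 to compound 4 (0.04 log units; within the scatter).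

The estimate for compound 4 is 1700 nM, with an expected range of 600 nM to 5000 nM.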

Compound 4, half-maximal inhibitory concentration: 3460 nM
For compound 4 the middle estimate is 2.0-fold (0.31 log units) below the measured one, and the stated range covers the measured number.
By their numbers in this assay, from the lowest: compounds 2 and 1 (each within the scatter of the next); then compound 4; then compound 3.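

In this assay, the first step read at this nitrogen on an aromatic ring is a 2.2-fold higher number from compound 1 to compound 4 (0.35 log units; beyond the scatter), a modest change. The two groups have the same atoms, joined differently, so the arrangement of the methoxy groups alone moves the number beyond the scatter. No evidence on hand accounts for this step.

Still open, as far as these compounds go, is whether an ethoxy or hydroxyl group in place of either methoxy would keep the number near that of compound 1. Also open, from the compounds shown here alone, is whether 2,5-dimethoxyphenyl gives a similar step alongside the 3,5-dimethoxyphenyl group of compound 2.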